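This account rests on a few compounds, and the source may have more. Where it says the series, first, only, none or still open, it means among the compounds named here.

Measured compounds:
- compound 1, `COc1ccc2nc(C)cc(OCC(=O)Nc3cc(C)cc(C)c3)c2c1`: 26000 nM
- compound 2, `Cc1cc(C)cc(NC(=O)COc2cc(C)nc3ccccc23)c1`: 55000 nM
- compound 3, `CSc1ccc2nc(C)cc(OCC(=O)Nc3cc(C)cc(C)c3)c2c1`: 3000 nM

In a physicochemical assay for solubility, in phosphate buffer, measured as kinetic solubility, with a stated time of 1 h, at pH 7.4 (a higher number here means a more soluble compound, a lower number a less soluble compound), compound 2 gives the highest number of the three, with compound 1 next and compound 3 furthest away. Compound 4, `Cc1cc(C)cc(NC(=O)COc2cc(C)nc3ccc(F)cc23)c1`, has not yet been measured; it differs from compound 2 by fluoro in place of hydrogen on an aromatic carbon. Going by the values given here, two measured steps bear on putting a group at that carbon of the shared core: a 2.1-fold higher number from compound 1 to compound 2 (0.33 log units; beyond the scatter) shows that removing the methoxy raised the number, and an 18-fold lower number from compound 2 to compound 3 (1.26 log units; beyond the scatter) shows that adding a methylsulfanyl lowered it strongly. Both point the same way, so a drop is expected for compound 4 in this assay, though a small one, since fluoro is a single heavy atom; the expected step is a 1.6-fold lower number from compound 2 to compound 4 (0.20 log units; within the scatter). Compound 4 is therefore estimated at 35000 nM, within 15000 nM to 70000 nM.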

Compound 4, solubility: 28000 nM
For compound 4 the middle estimate is 1.3-fold (0.10 log units) above the measured one, and the stated range covers the measured number.
By their numbers in this assay, from the lowest: compound 3; then compounds 1, 4 and 2 (each within the scatter of the next, the first and the last beyond it).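

In this assay, fluoro at this aromatic carbon cannot be told apart from hydrogen, with a 2.0-fold lower number from compound 2 to compound 4 (0.29 log units; within the scatter), or from methoxy, with a 1.1-fold higher number from compound 1 to compound 4 (0.03 log units; within the scatter). The low number of compound 3 is therefore not shared by every group placed here, as a 9.3-fold higher number from compound 3 to compound 4 (0.97 log units; beyond the scatter) shows. Nothing measured here explains these differences. Still open, on these data alone, is whether chloro, another single heavy atom, would behave like fluoro or like methylsulfanyl. An amine, a carboxylic acid or a longer chain such as ethoxy at this carbon also remains untested among the compounds shown.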